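Benzyloxy in place of methoxy on a shared core

The compounds below may be only part of what the source reports. "The series", "measured", "known", "first", "only" and "open" are said of these compounds alone.

Measured compounds:
compound 1 `COc1nc(N2CCN(C)CC2)nc(OC)c1Sc1cccc(NC(=O)CN)c1`, 25 uM
compound 2 `COc1nc(N2CCN(C)CC2)ncc1Sc1cccc(NC(=O)CN)c1`, 15 uM

In a functional assay on SK-BR-3 cells (Homo sapiens) for cytotoxicity, read by resazurin assay, with a stated time of 72 h (a higher number here means a weaker inhibitor of growth, a lower number a stronger inhibitor of growth), compound 2 gives 15 uM, the lower of the two numbers, while compound 1 gives 25 uM. Within the data shown here, the only measured step is a 1.7-fold lower number from compound 1 to compound 2 (0.22 log units; within the scatter), so the two compounds cannot be set apart. Compound 3 `CN1CCN(c2ncc(Sc3cccc(NC(=O)CN)c3)c(OCc3ccccc3)n2)CC1` is not yet measured. It differs from compound 2 by phenyl in place of hydrogen on a saturated chain carbon bound to an oxygen on an aromatic ring. Among the measured compounds shown here, no measured step touches this kind of change; the one step known concerns a different group and stays within the scatter, which gives no sign that this region of the shared core moves the numbers strongly. The expectation for compound 3 in this assay is therefore a step of no change at the digits printed from compound 2 to compound 3 (within the scatter), that is, no change beyond the scatter. Compound 3 is estimated at 15 uM, within a range from 5 uM to 45 uM.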

Compound 3, concentration for growth inhibition (reported as GI): 2.1 uM
Compound 3: middle estimate off by 7.1-fold (0.85 log units), on the high side; the whole stated range lies above it.
By their numbers in this assay, from the lowest: compound 3; then compounds 2 and 1 (each within the scatter of the next).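

In this assay the change from the methoxy of compound 2 to the benzyloxy of compound 3 gives a 7.1-fold lower number from compound 2 to compound 3 (0.85 log units; beyond the scatter) and is the only step shown that passes beyond the scatter. It shows that the numbers respond to what sits on this saturated chain carbon bound to an oxygen on an aromatic ring, something the earlier step between compound 1 and compound 2 could not show, as it concerned a different group. Nothing measured here explains why adding the phenyl goes with a lower number.

From the compounds shown here alone, it remains open whether the phenyl ring itself is needed or any larger group would do. An ethoxy or a cyclohexylmethoxy group in the same place would help to separate these two possibilities.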